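This account rests on a few compounds, and the source may have more. Where it says the series, first, only, none or still open, it means among the compounds named here.

Compound 1 `CC(C)NC(=O)N(O)CC1=Cc2cc(Oc3ccccc3)ccc2OC1`: 49 nM
Compound 2 `C=CCNC(=O)N(O)CC1=Cc2cc(Oc3ccccc3)ccc2OC1`: 37 nM

Both numbers come from an assay (Cavia porcellus) for inhibition of Polyunsaturated fatty acid 5-lipoxygenase (Homo sapiens); on this read-out lower numbers stand for stronger inhibition and higher numbers for weaker inhibition. Compound 2 stands nearest to compound 1 on these numbers, and the one step shown between them, a 1.3-fold lower number from compound 1 to compound 2 (0.12 log units; within the scatter), is within the scatter, so the two compounds cannot be told apart on this read-out.

Compound 3 `CCOC(=O)CNC(=O)N(O)CC1=Cc2cc(Oc3ccccc3)ccc2OC1` has not yet been measured. It differs from compound 2 in one place: ethoxycarbonyl in place of vinyl on a saturated chain carbon bound to an amide-type nitrogen. Going by the values given here, only one measured step bears on this change, and only loosely: the step from compound 1 to compound 2 also swaps the group on the same amide-type nitrogen, and it stayed within the scatter. Nothing measured here shows what an ethoxycarbonyl group does at this position, so no direction can be read from the data. The expected step is a 1.2-fold higher number from compound 2 to compound 3 (0.09 log units; within the scatter), that is, no change beyond the scatter, with a wide range to allow for the unknown group. Compound 3 is therefore estimated at 45 nM in this assay, with a range from 18 nM to 120 nM.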

Compound 3, half-maximal inhibitory concentration: 68 nM
Compound 3: middle estimate off by 1.5-fold (0.18 log units), on the low side; low and high end bracket the measured number.
By their numbers in this assay, from the lowest: compounds 2, 1 and 3 (each within the scatter of the next).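

Until now the group on this amide-type nitrogen had only been varied between two small hydrocarbon groups, isopropyl and allyl. Compound 3 puts something of a different kind there: ethoxycarbonyl carries 5 heavy atoms where vinyl carries 2, and 2 hydrogen-bond acceptors where vinyl has none, yet this assay shows a 1.8-fold higher number from compound 2 to compound 3 (0.26 log units; within the scatter) and, measured against the isopropyl group, a 1.4-fold higher number from compound 1 to compound 3 (0.14 log units; within the scatter). So among these three compounds, neither the added atoms nor the ester group moves the number beyond the usual scatter, and all three remain indistinguishable on this read-out. Nothing available here explains why the three compounds read alike.

Three compounds cannot show how far this insensitivity extends, since a carboxylic acid in place of the ethyl ester, an amine on the chain or a longer chain might each give a different result. Going by these compounds, it also remains open whether the number would hold with a ring on this nitrogen, or with no carbon group there at all, just the bare amide hydrogens.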